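The source may hold more compounds than are shown below. What is called first, only, known or untested is meant among the compounds shown, and "the series" means these compounds.

In a functional assay for inhibition, with Homo sapiens as the target (on this read-out lower numbers stand for an effect already at smaller amounts and higher numbers for an effect only at larger amounts of compound), compound 1 (`CC(=O)Nc1ccc(C2=NNC(=O)CC2)cc1`) gives 1 ug/mL and compound 2 (`CCCCC(=O)Nc1ccc(C2=NNC(=O)CC2)cc1`) gives 2.64 ug/mL on the same read-out. Compound 3 (`O=C1CCC(c2ccc(NC(=O)CCCCl)cc2)=NN1`) stands at > 46.4 ug/mL as a limit of the assay and not a number. Its standing in the series is the limit of > 46.4 ug/mL in this assay, at which 1 of the 3 values shown sits, and nothing firmer.

The next change leads to compound 4 (`CC(C)NCC(=O)Nc1ccc(C2=NNC(=O)CC2)cc1`), with isopropylamino in place of 2-chloroethyl on a saturated chain carbon bound to a carbonyl carbon and isopropylamino in place of 2-chloroethyl on a saturated chain carbon bound to a carbonyl carbon as the counted difference. Among the compounds with values here, the steps that bear on this change lie in the same chain: a 2.6-fold higher number from compound 1 to compound 2 (0.42 log units; beyond the scatter) is modest, whereas an at least 46-fold higher number from compound 1 to compound 3 (1.66 log units; beyond the scatter) and an at least 17-fold higher number from compound 2 to compound 3 (1.24 log units; beyond the scatter) are large. Within the data shown here, the large steps both end at compound 3, the only chloro compound, and compound 4 carries no chloro. The expectation therefore leans on compound 2 at 2.64 ug/mL as a chloro-free chain that stays close to compound 1. Among the measured compounds shown here, no measured compound carries isopropylamino, so the uncertainty is wide.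

A sizeable step to a lower number is expected in this assay, estimated as an at least 9.2-fold lower number from compound 3 to compound 4 (0.96 log units; beyond the scatter) on this reasoning. Compound 4 is estimated at 5 ug/mL in this read-out, with 0.8 ug/mL to 40 ug/mL as the expected range.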

Compound 4, half-maximal effective concentration: about 46.4 ug/mL
Compound 4: middle estimate off by 9.3-fold (0.97 log units), on the low side; measured number above the stated range.
By their numbers in this assay, from the lowest: compound 1; then compound 2; then compound 4.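

At the saturated chain carbon bound to a carbonyl carbon, a large step to a higher number in this assay no longer belongs to the chloro compound alone: isopropylamino in place of propyl gives an 18-fold higher number from compound 2 to compound 4 (1.24 log units; beyond the scatter), and isopropylamino in place of hydrogen gives a 46-fold higher number from compound 1 to compound 4 (1.67 log units; beyond the scatter). Leaving out chlorine is therefore not enough to keep the number near that of compound 1, and among the chlorine-free chains, propyl and isopropylamino part widely. Compound 3 remains a limit of the assay, so isopropylamino in place of 2-chloroethyl can be read only as a number no higher from compound 3 to compound 4 (the limit leaves the size open): the limit of > 46.4 ug/mL in this assay, at which 1 of the 4 values shown sits.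

It remains open whether the high number of compound 4 goes with the amine nitrogen or with the branched isopropyl end, since the compounds shown include neither a plain aminomethyl chain nor an unbranched propylamino chain at this carbon. Also open, on these data alone, is how a carboxylic acid, or a carbon chain longer than propyl, would read at the same place.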